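Longer chain on compound 2: working notes

The compounds below may be only part of what the source reports. "The series", "measured", "known", "first", "only" and "open" are said of these compounds alone.

Values in a functional assay on HCT-116 cells (Homo sapiens) for antiproliferative activity, read by MTT assay, with a stated time of 48 h; on this read-out lower numbers stand for stronger inhibition and higher numbers for weaker inhibition:
compound 1 (`CCCCCCC(CCO)n1cnc2c(Cl)ncnc21`) gives 11900 nM
compound 2 (`CCCCCCC(CCO)n1cnc2c(NC)ncnc21`) gives a limit, > 50000 nM
compound 3 (`CCCCCCC(CCO)n1cnc2cncnc21`) gives a limit, > 50000 nM

Compound 2 stands only at a limit (> 50000 nM), not at a number. The change to compound 4 (`CCCCCCCC(CCO)n1cnc2c(NC)ncnc21`) is methyl in place of hydrogen on a saturated chain carbon, seven bonds along the chain from an aromatic nitrogen. Among the compounds with values here, no measured step touches the chain. Those at the group on the shared core bear only indirectly: (an at least 4.2-fold higher number from compound 1 to compound 2 (0.62 log units; beyond the scatter)) and (an at least 4.2-fold higher number from compound 1 to compound 3 (0.62 log units; beyond the scatter)) lie beyond the scatter, while (a step that the two limits leave unreadable from compound 2 to compound 3) cannot be read. Compound 4 keeps the methylamino group that accompanies the loss of a number in the step (an at least 4.2-fold higher number from compound 1 to compound 2 (0.62 log units; beyond the scatter)). No step beyond the scatter is therefore expected in this assay (a number no higher from compound 2 to compound 4 (the limit leaves the size open)). For compound 4 the estimated value is 50000 nM, with an expected range from 20000 nM to 100000 nM (a limit is the likely report).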

Compound 4, half-maximal inhibitory concentration: 12500 nM
Compound 4: the middle estimate sits 4.0-fold (0.60 log units) above what was measured; the whole stated range lies above it.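

In this assay the saturated chain proves to be a place where a single added carbon counts: methyl in place of hydrogen gives an at least 4.0-fold lower number from compound 2 to compound 4 (0.60 log units; beyond the scatter), the first step read away from the group on the shared core. The methylamino group therefore does not rule out a measurable number, since compound 4 keeps it. The true size of the step remains unknown because compound 2 stands at a limit: the limit of > 50000 nM in this assay, at which 2 of the 4 values shown sit.

As far as these compounds go, whether a longer chain lowers the number further stays open. So does what the chloro group would give on the chain of compound 4.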